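Halophenyl substitution on the shared core: anilino swap

This account rests on a few compounds, and the source may have more. Where it says the series, first, only, none or still open, it means among the compounds named here.

Compound 2 `COc1ccc(Nc2nc(Nc3cc(C)[nH]n3)cc(N3CCN(C)CC3)n2)cc1OC` gives 150 nM in a functional assay on U-937 cells (Homo sapiens) for antiproliferative activity, read by CCK-8 assay, with a stated time of 48 h (a higher number here means a weaker inhibitor, a lower number a stronger inhibitor), the highest of the two numbers recorded; its nearest neighbour is compound 1 `Cc1cc(Nc2cc(N3CCN(C)CC3)nc(Nc3ccc(F)cc3)n2)n[nH]1`, which gives 43.2 nM. Among the compounds with values here, the one step measured, a 3.5-fold higher number from compound 1 to compound 2 (0.54 log units; beyond the scatter), accompanies the exchange of 4-fluorophenyl for 3,4-dimethoxyphenyl on the nitrogen on the aromatic ring. Compound 3 `Cc1cc(Nc2cc(N3CCN(C)CC3)nc(Nc3ccc(Cl)c(F)c3)n2)n[nH]1` reverses part of that change: 4-chloro-3-fluorophenyl in place of 3,4-dimethoxyphenyl on a nitrogen on an aromatic ring. Within the data shown here, the group entering, 4-chloro-3-fluorophenyl, resembles the 4-fluorophenyl of compound 1 more than the group leaving, so the step measured from compound 1 to compound 2 is the only guide and points the other way. The expected step is therefore a 3.0-fold lower number from compound 2 to compound 3 (0.48 log units; beyond the scatter), a lower number for compound 3, of about the size seen between compound 1 and compound 2. Compound 3 is accordingly estimated at 50 nM, with a range from 18 nM to 140 nM in this assay.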

Compound 3, half-maximal inhibitory concentration: 24.8 nM
The estimate for compound 3 lay 2.0-fold (0.30 log units) above the measured number; the range from low to high includes it.
By their numbers in this assay, from the lowest: compounds 3 and 1 (each within the scatter of the next); then compound 2.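

At this position, on a nitrogen on an aromatic ring, a second halogen-bearing phenyl group also stands apart from the 3,4-dimethoxyphenyl group: in this assay, 4-chloro-3-fluorophenyl in place of 3,4-dimethoxyphenyl gives a 6.0-fold lower number from compound 2 to compound 3 (0.78 log units; beyond the scatter). Among the halogen-bearing groups, 4-chloro-3-fluorophenyl in place of 4-fluorophenyl gives a 1.7-fold lower number from compound 1 to compound 3 (0.24 log units; within the scatter), so adding chlorine and a second fluorine to the ring produces no separable change. Nothing available explains the difference between the 3,4-dimethoxyphenyl group and the two halogen-bearing groups.

Within the data shown here, with only three compounds, it remains open whether the halogens or the two methoxy groups account for the gap. An unsubstituted phenyl and a 4-methoxyphenyl group on this nitrogen would help separate those two readings.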